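Swapping the heteroaryl group on the amine of compound 3

A few compounds are considered here, and "the series" means these few. Any claim that something is new, unique, unknown or untested is made for them only; others in the source may bear on it.

Measured compounds:
compound 1 `CCO/C(O)=C1\C(COCCNc2n[nH]c(N)n2)=NC(C)=C(C(=O)OC)C1c1cccc(Cl)c1`: 126 nM
compound 2 `CCO/C(O)=C1\C(COCCNc2n[nH]c(N)n2)=NC(C)=C(C(=O)OC)C1c1cccc(C(F)(F)F)c1Cl`: 3.98 nM
compound 3 `CCO/C(O)=C1\C(COCCNc2n[nH]c(O)n2)=NC(C)=C(C(=O)OC)C1c1cccc(Cl)c1Cl`: 10 nM

All three were tested in a functional assay (aorta) with Rattus norvegicus as the target; on this read-out lower numbers stand for stronger inhibition and higher numbers for weaker inhibition. Compound 3 stands second highest of the three numbers; its nearest neighbour is compound 2 and its furthest is compound 1, both gaps lying beyond the scatter.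

Compound 4 `CCO/C(O)=C1\C(COCCNc2n[s+]([O-])nc2N)=NC(C)=C(C(=O)OC)C1c1cccc(Cl)c1Cl` differs from compound 3 at the amine nitrogen, whose other neighbour is a saturated chain carbon: a group of 7 heavy atoms (2 carbon, 3 nitrogen, 1 oxygen, 1 sulfur; one five-membered aromatic ring with 3 hetero atoms) in place of a group of 6 heavy atoms (2 carbon, 3 nitrogen, 1 oxygen; one five-membered aromatic ring with 3 hetero atoms), on an amine nitrogen. The 5-hydroxy-1H-1,2,4-triazol-3-yl group leaves, and a group with one more heavy atom, one donor fewer and one acceptor more enters.

Among the compounds with values here, only one single-point step between measured compounds is known, a 32-fold lower number from compound 1 to compound 2 (1.50 log units; beyond the scatter), and it concerns the aryl group on the saturated ring carbon, not the group on the amine nitrogen, so it does not bear on this change. Compounds 2 and 3 differ in two places at once; their values show only that both lie far below compound 1.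

Within the data shown here, with no step touching the amine substituent, the expected change in this assay is uncertain, and a modest step in either direction or none beyond the scatter is plausible. The estimated step is a 1.5-fold higher number from compound 3 to compound 4 (0.18 log units; within the scatter). Compound 4 is therefore expected to give about 15 nM, within a range from 4 nM to 60 nM.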

Compound 4, half-maximal inhibitory concentration: 15.9 nM
Beside the measured number, compound 4's estimate is 1.1-fold (0.03 log units) below it; measured number inside the range.
By their numbers in this assay, from the lowest: compound 2; then compounds 3 and 4 (each within the scatter of the next); then compound 1.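

In this assay, within the data shown here, putting the sulfur-containing five-membered aromatic ring with 3 hetero atoms on the amine nitrogen in place of the 5-hydroxy-1H-1,2,4-triazol-3-yl group gives a 1.6-fold higher number from compound 3 to compound 4 (0.20 log units; within the scatter) and this is the first reading of a change at this position alone, since the only earlier single-place step concerned the aryl group on the saturated ring carbon. Compounds 3 and 4 therefore cannot be told apart in this read-out, which shows that this position can carry two different rings, with different counts of hydrogen-bond donors and acceptors, without a difference beyond the scatter. No measurement given here accounts for this result.

This single pair, on one aryl group and one chain, does not show how far the finding extends to rings of other kinds, such as a pyridine or a phenyl group on the amine nitrogen. The compounds shown also leave open what a free primary amine in place of the ring, or a longer chain leading to it, would give in this read-out.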